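The source may report more compounds than this note shows. Statements on the series, on what has been measured and on what is new or still open speak of the compounds shown alone.

Working notes on the series. In an ADME assay on Vero cells (Chlorocebus sabaeus) for cytotoxicity, read by MTT assay, with a stated time of 72 h (on this read-out higher numbers stand for weaker inhibition and lower numbers for stronger inhibition), compound 1 `Cc1c(C(=O)OCc2ccccc2)[n+]([O-])c2cc(F)c(F)cc2[n+]1[O-]` gives 55300 nM and compound 2 `CCOC(=O)c1c(C)[n+]([O-])c2cc(-n3cncn3)c(F)cc2[n+]1[O-]` gives 155000 nM as its reading. Compound 3 `Cc1c(C(=O)OCc2ccccc2)[n+]([O-])c2cc(F)c(-n3ccnc3)cc2[n+]1[O-]` gives 107000 nM in this assay and lies within the scatter of both other compounds. Compound 4 `Cc1c(C(=O)OCc2ccccc2)[n+]([O-])c2cc(F)c(-n3cncn3)cc2[n+]1[O-]` is still unmeasured. Its change from compound 3 is 1H-1,2,4-triazol-1-yl in place of 1H-imidazol-1-yl on an aromatic carbon, ortho to a fluoro group: 1H-1,2,4-triazol-1-yl in place of 1H-imidazol-1-yl on an aromatic carbon is the full count.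

Among the compounds with values here, the only measured step in the set is a 1.9-fold higher number from compound 1 to compound 3 (0.29 log units; within the scatter) and it lies within the scatter. That step is a different exchange, 1H-imidazol-1-yl in place of fluoro, so it bears on this change only indirectly. Compound 2 also carries 1H-1,2,4-triazol-1-yl, but it differs from compound 4 in more than that group. Within the data shown here, no measured pair exchanges these two groups directly. No step beyond the scatter is therefore expected in this assay, and the data set no direction.

The estimated step is a 1.1-fold higher number from compound 3 to compound 4 (0.03 log units; within the scatter) and it is expected to stay within the scatter. For compound 4 the expected value is 115000 nM with an estimated range from 55000 nM to 230000 nM in this read-out.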

Compound 4, half-maximal inhibitory concentration: 123000 nM
The estimate for compound 4 lay 1.1-fold (0.03 log units) below the measured number; low and high end bracket the measured number.
By their numbers in this assay, from the lowest: compounds 1, 3, 4 and 2 (each within the scatter of the next, the first and the last beyond it).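

In this assay, within the data shown here, the first direct exchange of the two rings on this aromatic carbon, ortho to a fluoro group, gives a 1.1-fold higher number from compound 3 to compound 4 (0.06 log units; within the scatter), so 1H-1,2,4-triazol-1-yl and 1H-imidazol-1-yl are not told apart here, although the entering ring has one more hetero atom. Among these compounds, the exchange of fluoro for 1H-1,2,4-triazol-1-yl at this place gives a 2.2-fold higher number from compound 1 to compound 4 (0.35 log units; beyond the scatter), the first step in the set beyond the scatter, though only a modest one, while the corresponding exchange for 1H-imidazol-1-yl gives a 1.9-fold higher number from compound 1 to compound 3 (0.29 log units; within the scatter). The ester comparison gives a 1.3-fold lower number from compound 2 to compound 4 (0.10 log units; within the scatter), with phenyl in place of methyl on the saturated chain carbon, but the two structures also carry 1H-1,2,4-triazol-1-yl at different places, so this step cannot be assigned to the phenyl alone.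

Nothing on hand accounts for any of these steps. Going by these compounds, it remains open whether an amine or a carboxylic acid on this aromatic carbon would give a number beyond the scatter of compound 4.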